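Working notes: a longer link from compound 1

The compounds below may be only part of what the source reports. "The series", "measured", "known", "first", "only" and "open" are said of these compounds alone.

In an ADME assay on microsomes from liver (Homo sapiens) for metabolic stability (on this read-out higher numbers stand for a longer-lived compound and lower numbers for a shorter-lived compound), compound 1 (`CC(C)[C@@H](c1ccc(-c2ccc3cccc(F)c3c2)[nH]c1=O)[C@@H]1OC(=O)NC1=O`) reads > 3 h as a limit of the assay and not a number. Compound 1 therefore stands at the limit of > 3 h in this assay, at which 2 of the 3 values shown sit, and has no exact rank. Compound 3 (`CC(C)C(/C=C1/C(=O)NC(=O)N1C)c1ccc(-c2ccc3cccc(F)c3c2)[nH]c1=O`) reads > 3 h as a limit of the assay as well. Among the compounds with values here, compound 2 (`O=C1NC(=O)/C(=C/C(c2ccc(-c3ccc4cccc(F)c4c3)[nH]c2=O)C2CC2)O1`) gives 1.98 h as the only actual number in the set so far. No two of these compounds differ in one place only, so no measured step can be carried over.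

Compound 4 (`CC(C)[C@H](C[C@@H]1OC(=O)NC1=O)c1ccc(-c2ccc3cccc(F)c3c2)[nH]c1=O`) is still to be measured. It carries (2,4-dioxo-1,3-oxazolidin-5-yl)methyl in place of 2,4-dioxo-1,3-oxazolidin-5-yl on a saturated chain carbon bound to an aromatic carbon and a saturated chain carbon.

The expected step of a number no higher from compound 1 to compound 4 (the limit leaves the size open) in this assay is none beyond the scatter, with no direction favoured. The expectation starts from compound 1 at > 3 h as a limit. Compound 2 at 1.98 h keeps a numerical reading in view as the expected alternative. For compound 4 the estimated half-life is 3 h with an expected range from 1.6 h to 5 h in this assay and a fair chance of another limit reading.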

Compound 4, half-life: 2.07 h
Beside the measured number, compound 4's estimate is 1.4-fold (0.16 log units) above it; the range from low to high includes it.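

Within the data shown here, the change of 2,4-dioxo-1,3-oxazolidin-5-yl to (2,4-dioxo-1,3-oxazolidin-5-yl)methyl, on a saturated chain carbon bound to an aromatic carbon and a saturated chain carbon, gives the first measured step at this position: in this assay the series shows an at least 1.4-fold lower number from compound 1 to compound 4 (0.16 log units; that floor lies within the scatter). Compound 4 gives 2.07 h, an actual number, so the longer link can be placed on the read-out, and the step shows no change beyond the scatter while leaving a larger one possible. The true size of the step cannot be fixed because compound 1 carries only a limit of the assay and not a number: the limit of > 3 h in this assay, at which 2 of the 4 values shown sit.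

Whether the longer link truly shortens half-life therefore remains undecided, and a reading for compound 1 below the limit would be needed to settle it. Also open, as far as these compounds go, is how this position responds to a still longer chain, such as (2,4-dioxo-1,3-oxazolidin-5-yl)ethyl, or to a carboxylic acid or an amine in place of the 2,4-dioxo-1,3-oxazolidin-5-yl group.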